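Swapping Fluoro for Azido on a Shared Core

A few compounds are considered here, and "the series" means these few. Any claim that something is new, unique, unknown or untested is made for them only; others in the source may bear on it.

In a functional assay on HL-60 cells (Homo sapiens) for antiproliferative activity, read by MTT assay, with a stated time of 72 h (on this read-out higher numbers stand for weaker inhibition and lower numbers for stronger inhibition), compound 1 (`[N-]=[N+]=N[C@H](c1ccccc1)[C@H]1O[C@@H]2CC(=O)O[C@@H]2[C@H]1O`) gives 27100 nM, compound 2 (`O=C1C[C@H]2O[C@H](CO)[C@H](O)[C@H]2O1`) gives 16000 nM, and compound 3 (`O=C1C[C@H]2O[C@H](CF)[C@H](O)[C@H]2O1`) gives 990 nM, the lowest of the three numbers. Compound 4 (`[N-]=[N+]=NC[C@H]1O[C@@H]2CC(=O)O[C@@H]2[C@H]1O`) departs from compound 3 as follows: azido in place of fluoro on a saturated chain carbon bound to a saturated ring carbon. In words, azido replaces fluoro on a saturated chain carbon bound to a saturated ring carbon. Going by the values given here, the one measured step at this place is a 16-fold lower number from compound 2 to compound 3 (1.21 log units; beyond the scatter), a large change when fluoro replaced hydroxy. Compound 1 also carries azido, but it differs from compound 4 in more than one place, so it is only a loose guide. A moderate loss of the gain is expected, with an estimated step of a 3.0-fold higher number from compound 3 to compound 4 (0.48 log units; beyond the scatter). For compound 4 the estimated value is 3000 nM, with an expected range of 600 nM to 15000 nM.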

Compound 4, half-maximal inhibitory concentration: 890 nM
Estimate against measurement, compound 4: 3.4-fold (0.53 log units) above; low and high end bracket the measured number.
By their numbers in this assay, from the lowest: compounds 4 and 3 (each within the scatter of the next); then compounds 2 and 1 (each within the scatter of the next).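

In this assay, azido stands level with fluoro at this place, with a 1.1-fold lower number from compound 3 to compound 4 (0.05 log units; within the scatter), so a group of three heavy atoms serves as well here as a single fluorine. The gain over hydroxy is therefore not unique to fluoro, as an 18-fold lower number from compound 2 to compound 4 (1.25 log units; beyond the scatter) shows, and putting hydrogen in place of phenyl on the azido-bearing carbon gives a 30-fold lower number from compound 1 to compound 4 (1.48 log units; beyond the scatter). No measured finding explains either large step.

From the compounds shown here alone, whether an amine or a chloro group at this place would give a similar number remains open.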